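A few compounds are considered here, and "the series" means these few. Any claim that something is new, unique, unknown or untested is made for them only; others in the source may bear on it.

Working notes on the series in a functional assay on blood (Homo sapiens) for inhibition; on this read-out higher numbers stand for weaker inhibition and lower numbers for stronger inhibition. Of the compounds shown here, three carry a number so far. Compound 1 `C[S+]([O-])c1ccc(CSc2nc(-c3ccc(F)cc3)c(-c3ccncc3)[nH]2)cc1` gives 380 nM. Compound 2 `CSc1nc(-c2ccc(F)cc2)c(-c2ccnc(NC3CCCCC3C)c2)[nH]1` gives 136 nM. Compound 3 `CSc1nc(-c2cccc(C(F)(F)F)c2)c(-c2ccnc(NC(C)C(C)C)c2)[nH]1` gives 1360 nM. Compound 2 thus stands lowest of the three: compound 1 sits nearest to it, with a gap beyond the scatter, and compound 3 sits furthest, again beyond the scatter. Since compound 1 and compound 3 each differ from compound 2 in more than one place, none of these gaps can be assigned to a single change.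

Compound 4 `CCC(Nc1cc(-c2[nH]c(SC)nc2-c2ccc(F)cc2)ccn1)c1ccccc1` has not been measured. Relative to compound 2 the change is 1-phenylpropyl in place of 2-methylcyclohexyl on a nitrogen on an aromatic ring. Nothing in the measured set isolates a change at this nitrogen, so the size of the step has to be judged without a precedent. The working expectation is a small step from compound 2 to compound 4, of about a 1.5-fold higher number from compound 2 to compound 4 (0.17 log units; within the scatter), with no firm direction and likely within or only just beyond the scatter. On that basis compound 4 is estimated at 200 nM, with a range from 60 nM to 700 nM, and the measurement will show whether the replacement of the 2-methylcyclohexyl group moves the series at all.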

Compound 4, half-maximal inhibitory concentration: 7640 nM
Compound 4: middle estimate off by 38-fold (1.58 log units), on the low side, and the stated range ends below it.
By their numbers in this assay, from the lowest: compound 2; then compound 1; then compound 3; then compound 4.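

Among these compounds, the pair gives the first single-place step: in this assay, 1-phenylpropyl in place of 2-methylcyclohexyl on a nitrogen on an aromatic ring brings a 56-fold higher number from compound 2 to compound 4 (1.75 log units; beyond the scatter), so the number in this read-out depends strongly on the group at this nitrogen. The step replaces one six-membered non-aromatic ring of carbon only, in a group of 7 heavy atoms, with one six-membered aromatic ring of carbon only, in a group of 9 heavy atoms, and neither group has hydrogen-bond donors or acceptors, so the ring type and the group size change together and this single pair cannot separate them. Nothing in the data bears on the reason for the size of the step.

Still open, on these data alone, is whether cyclohexyl without the methyl, or benzyl or 1-phenylethyl, on the same nitrogen would stand nearer to compound 2 or to compound 4. Also open, as far as these compounds go, is how a group with a hydroxyl or an amine on the cyclohexyl ring would read at this nitrogen, and whether the step would be the same size with a trifluoromethyl group on the other aryl ring.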